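A Second Nitro Group on the Aromatic Ring

The source may report more compounds than this note shows. Statements on the series, on what has been measured and on what is new or still open speak of the compounds shown alone.

Compounds measured in a functional assay for inhibition, read by spectrophotometry, with a stated time of 120 min; on this read-out lower numbers stand for stronger inhibition and higher numbers for weaker inhibition:
compound 1 `CCOC(=O)N1CCC(=NNC(=O)c2ccc(Cl)cc2)CC1`: 72300 nM
compound 2 `CCOC(=O)N1CCC(=NNC(=O)c2ccc([N+](=O)[O-])cc2)CC1`: 40200 nM

Compound 2 gives the lowest of the two numbers recorded so far; its nearest neighbour is compound 1, and the step of a 1.8-fold lower number from compound 1 to compound 2 (0.25 log units; within the scatter) lies within the scatter, so the two compounds cannot be placed in order on this read-out.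

Compound 3 `CCOC(=O)N1CCC(=NNC(=O)c2ccc([N+](=O)[O-])cc2[N+](=O)[O-])CC1` differs from compound 2 by one change: nitro in place of hydrogen on an aromatic carbon. Among the measured compounds shown here, no measured pair shows the effect of adding a further nitro group to a ring that already carries one. For the measured compounds named here, the only measured step, a 1.8-fold lower number from compound 1 to compound 2 (0.25 log units; within the scatter), concerns a swap of chloro for nitro and was within the scatter; it gives no ground to expect a shift beyond the scatter here either. The step of a 1.1-fold lower number from compound 2 to compound 3 (0.06 log units; within the scatter) is therefore the expectation, with wide uncertainty. Compound 3 is estimated at 35000 nM, in a range from 12000 nM to 110000 nM.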

Compound 3, half-maximal inhibitory concentration: 27800 nM
Compound 3: the middle estimate sits 1.3-fold (0.10 log units) above what was measured; low and high end bracket the measured number.
By their numbers in this assay, from the lowest: compounds 3, 2 and 1 (each within the scatter of the next, the first and the last beyond it).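

In this assay, a nitro group entering on the aromatic carbon ortho to a large group and meta to a nitro group gives a 1.4-fold lower number from compound 2 to compound 3 (0.16 log units; within the scatter). Among the compounds shown here, the earlier compounds showed only one group swapped for another, whereas this pair shows that filling this hydrogen-bearing position with 3 further heavy atoms does not separate compound 3 from compound 2 on this read-out, so the position tolerates a nitro group without a shift that can be told from the scatter. Nothing available accounts for this outcome in terms of any property of the group.

The compounds shown leave open whether an amine, a carboxylic acid or a methoxy group at this position would move the number beyond the scatter. They also leave open whether a nitro group here would behave the same way with chloro in place of the first nitro group.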